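Hydroxy to methoxy on the amide ring: forecasting compound 4

This account rests on a few compounds, and the source may have more. Where it says the series, first, only, none or still open, it means among the compounds named here.

Compound 1 `CC(C)(CNC(=O)c1ccccc1O)CC1=C(O)C(=O)c2ccccc2C1=O` gives 28100 nM
Compound 2 `CC(C)(CNC(=O)c1ccc2ccccc2c1O)CC1=C(O)C(=O)c2ccccc2C1=O` gives 79500 nM
Compound 3 `COC1=C(CC(C)(C)CNC(=O)c2ccccc2OC)C(=O)c2ccccc2C1=O` gives 70700 nM

All three numbers come from a functional assay on MCF7 cells (Homo sapiens) for cytotoxicity, read by resazurin assay, with a stated time of 3 days; a lower number here means a stronger inhibitor, a higher number a weaker inhibitor. Among them compound 2 has the highest number; compound 3 is within the usual scatter of it, whereas compound 1 sits beyond the scatter at a lower number. For the measured compounds named here, compound 1 and compound 3 differ in more than one place, so their two values show only that the fully methylated compound 3 gives the higher number.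

Compound 4 `COc1c(C(=O)NCC(C)(C)CC2=C(O)C(=O)c3ccccc3C2=O)ccc2ccccc12` is not yet measured in this assay. It differs from compound 2 by methyl in place of hydrogen on an oxygen on an aromatic ring; read one bond further out, hydroxy becomes methoxy. The core of compound 2 with its free hydroxy is kept.

Going by the values given here, since no single-place step among the measured compounds is available, the size of this change has to be guessed. Because compound 3 gives 70700 nM with methoxy groups throughout, and compound 2 is already at the high end of the set, the expected step is small and most likely toward a higher number, though it may well fall within the scatter. Compound 4 is expected to give 100000 nM in this assay, within 40000 nM to 250000 nM. This estimate means a 1.3-fold higher number from compound 2 to compound 4 (0.10 log units; within the scatter).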

Compound 4, half-maximal inhibitory concentration: 39800 nM
The estimate for compound 4 lay 2.5-fold (0.40 log units) above the measured number, and the stated range ends above it.
By their numbers in this assay, from the lowest: compounds 1, 4, 3 and 2 (each within the scatter of the next, the first and the last beyond it).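

In this assay, for the compounds shown here, the change from hydroxy to methoxy on the aromatic ring gives a 2.0-fold lower number from compound 2 to compound 4 (0.30 log units; within the scatter) and is the first change in this set that can be read in a single place. On the core of compound 2, then, methyl can take the place of hydrogen on this oxygen without a shift beyond the scatter, so the free hydroxy at this position is not needed to hold the number at this level in this cell assay. No measurement shown here accounts for this result.

On these data alone, the step comes from the larger amide ring of compound 2 alone, so whether the same change would behave alike on the smaller amide ring of compound 1 remains open, as does the separate contribution of the methoxy on the core of compound 3. Also open, as far as these compounds go, is how far this oxygen position tolerates change, for instance whether an ethyl group or a longer chain on the oxygen, or an amine in place of the hydroxy, would stay within the scatter.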